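The compounds below may be only part of what the source reports. "The series", "measured", "known", "first", "only" and "open" are said of these compounds alone.

Compound 3, `CCN1C(=O)N(CC)C2C1NC(=S)N2/N=C/C=C/c1ccccc1[N+](=O)[O-]`, gives 43900 nM in a functional assay on MCF7 cells (Homo sapiens) for inhibition, read by MTT assay, with a stated time of 72 h (on this read-out lower numbers stand for stronger inhibition and higher numbers for weaker inhibition), the highest of the three numbers at hand. Compound 2, `CCN1C(=O)N(CC)C2C1NC(=S)N2/N=C/C=C/c1ccccc1`, gives 36100 nM, and compound 1, `COc1ccccc1/C=C/C=N/N1C(=S)NC2C1N(C)C(=O)N2c1ccccc1`, gives 260 nM. Compound 4, `CCN1C(=O)N(CC)C2C1NC(=S)N2/N=C/C=C/c1ccccc1OC`, differs from compound 3 by methoxy in place of nitro on an aromatic carbon. For the measured compounds named here, the only measured step on the same core, a 1.2-fold higher number from compound 2 to compound 3 (0.08 log units; within the scatter), stayed within the scatter, so a change at this aromatic carbon has so far moved nothing. Compound 1 also carries a methoxy group, but on a different core, so its low number cannot be carried over. Compound 4 is therefore expected to show no step beyond the scatter, a 1.5-fold lower number from compound 3 to compound 4 (0.17 log units; within the scatter). The estimate for compound 4 is 30000 nM, with a range from 8000 nM to 120000 nM.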

Compound 4, half-maximal inhibitory concentration: > 100000 nM
Compound 4: no number, only a limit; the forecaster's own chance of this, stated with the estimate: 10%; middle value at least 3.3-fold (0.52 log units) away from the limit.
By their numbers in this assay, from the lowest: compound 1; then compounds 2 and 3 (each within the scatter of the next). At a limit, above all of these: compound 4.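

The position is not indifferent to what it carries: nitro in place of hydrogen had stayed within the scatter, whereas methoxy gives an at least 2.2-fold higher number from compound 3 to compound 4 (0.35 log units; beyond the scatter). For the compounds shown here, measured against hydrogen, methoxy gives an at least 2.7-fold higher number from compound 2 to compound 4 (0.44 log units; beyond the scatter), so only this group has so far moved the number at this aromatic carbon. Compound 4 has no exact number in this assay, only a limit, so both steps are minimum sizes: the limit of > 100000 nM in this assay, at which 1 of the 4 values shown sits.

On these data alone, the true size of the methoxy step remains open. So does whether an amine, a carboxylic acid or a longer alkoxy chain here would behave like hydrogen and nitro or like methoxy.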